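Swapping the benzyl group on compound 2

The source may hold more compounds than are shown below. What is called first, only, known or untested is meant among the compounds shown, and "the series" means these compounds.

Compound 1 `O=C(O)CN1C(=O)/C(=C/c2nc3ccccc3n2Cc2ccc(Br)cc2F)SC1=S`: 27300 nM
Compound 2 `O=C(O)CN1C(=O)/C(=C/c2nc3ccccc3n2Cc2ccc([N+](=O)[O-])cc2)SC1=S`: 11400 nM
Compound 3 `O=C(O)CN1C(=O)/C(=C/c2nc3ccccc3n2Cc2ccc(F)cc2F)SC1=S`: not yet measured

For the measured compounds named here, in a functional assay on A549 cells (Homo sapiens) for cytotoxicity, read by MTT assay, with a stated time of 48 h (on this read-out lower numbers stand for stronger inhibition and higher numbers for weaker inhibition), compound 2 has the lower of the two numbers so far, 11400 nM, which makes it the stronger inhibitor of this pair. The next structure changes one group: 2,4-difluorophenyl in place of 4-nitrophenyl on a saturated chain carbon bound to an aromatic nitrogen. In words, 2,4-difluorophenyl replaces 4-nitrophenyl on a saturated chain carbon bound to an aromatic nitrogen.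

Going by the values given here, only one measured step bears on this change, and it occurred at the same place: a 2.4-fold lower number from compound 1 to compound 2 (0.38 log units; beyond the scatter). That step was modest but beyond the scatter, and it brought in the 4-nitrophenyl that now leaves. The entering 2,4-difluorophenyl looks more like the 4-bromo-2-fluorophenyl of compound 1 than like 4-nitrophenyl. One step cannot establish a rule, but a modest move toward a higher number in this assay is expected, possibly close to the scatter. The expected change is a 1.8-fold higher number from compound 2 to compound 3 (0.27 log units; within the scatter). Compound 3 is estimated at 21000 nM, with an expected range of 9000 nM to 45000 nM.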

Compound 3, half-maximal inhibitory concentration: 12800 nM
For compound 3 the middle estimate is 1.6-fold (0.22 log units) above the measured one, and the stated range covers the measured number.
By their numbers in this assay, from the lowest: compounds 2 and 3 (each within the scatter of the next); then compound 1.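

At the saturated chain carbon bound to an aromatic nitrogen, this assay shows a 1.1-fold higher number from compound 2 to compound 3 (0.05 log units; within the scatter) for 2,4-difluorophenyl in place of 4-nitrophenyl, so two groups that differ in their atoms, one with 2 hydrogen-bond acceptors and the other with 0, cannot be told apart here. Until now, the lower number of compound 2 could have been read as tied to its 4-nitrophenyl, yet compound 3 carries no such group and still lies within the scatter of compound 2. A clearer difference appears with fluoro in place of bromo on an aromatic carbon, which gives a 2.1-fold lower number from compound 1 to compound 3 (0.33 log units; beyond the scatter) and, though modest, lies beyond the scatter, so that among these three only compound 1, the one carrying bromo, stands apart.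

Whether that holds for bromo alone stays open, since a chloro or an amine on the same ring is not among the compounds shown. Nothing shown here gives a reason for any of these numbers.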